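This account rests on a few compounds, and the source may have more. Where it says the series, first, only, none or still open, it means among the compounds named here.

Measured so far in an assay on isolated protein for inhibition of Rho-associated protein kinase 1 (Homo sapiens), read by scintillation counting, radiometric assay and 33P incorporation, with a stated time of 40 min, in the presence of a further agent that is not named here; on this read-out lower numbers stand for stronger inhibition and higher numbers for weaker inhibition:
compound 1 `CC(=O)Nc1cccc(NC(=O)COc2ccc3c(=O)ccoc3c2)c1` gives 2500 nM
compound 2 `N#Cc1ccc(C(=O)Nc2cccc(NC(=O)COc3ccc4c(=O)ccoc4c3)c2)cc1` gives 123 nM
compound 3 `O=C(COc1ccc2c(=O)ccoc2c1)Nc1cccc(NC(=O)c2cccc([N+](=O)[O-])c2)c1` gives 528 nM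

Compound 3 stands second highest of the three numbers; its nearest neighbour is compound 2, a 4.3-fold higher number from compound 2 to compound 3 (0.63 log units; beyond the scatter), and the furthest is compound 1, a 4.7-fold lower number from compound 1 to compound 3 (0.68 log units; beyond the scatter). Compound 4 `Cn1ccc(S(=O)(=O)Nc2cccc(NC(=O)COc3ccc4c(=O)ccoc4c3)c2)n1` differs from compound 3 in one place: a group of 9 heavy atoms (4 carbon, 2 nitrogen, 2 oxygen, 1 sulfur; one five-membered aromatic ring with 2 hetero atoms) in place of a group of 11 heavy atoms (7 carbon, 1 nitrogen, 3 oxygen; one six-membered aromatic ring of carbon only), on a nitrogen on an aromatic ring, on a nitrogen on an aromatic ring whose other neighbour is aromatic carbon. The steps at this nitrogen, a 20-fold lower number from compound 1 to compound 2 (1.31 log units; beyond the scatter) and a 4.7-fold lower number from compound 1 to compound 3 (0.68 log units; beyond the scatter), show that the position tolerates wide swings, but none of them exchanges a carbonyl for a sulfonyl or a carbon-only ring for one with two hetero atoms, so the direction is open. A modest step, likelier towards a higher number, is expected: a 1.9-fold higher number from compound 3 to compound 4 (0.28 log units; within the scatter). Compound 4 is estimated at 1000 nM, within 250 nM to 4000 nM.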

Compound 4, half-maximal inhibitory concentration: > 10000 nM
Compound 4: a limit, no number; the forecaster's own chance of this, stated with the estimate: 10%; middle value at least 10-fold (1.00 log units) away from the limit.
By their numbers in this assay, from the lowest: compound 2; then compound 3; then compound 1. At a limit, above all of these: compound 4.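

Compound 4 stands at a limit of the assay, not at a number: the limit of > 10000 nM in this assay, at which 1 of the 4 values shown sits. The earlier steps shown here at this nitrogen all ran to lower numbers from compound 1, whereas this change runs the other way, with an at least 18-fold higher number from compound 3 to compound 4 (1.27 log units; beyond the scatter) and an at least 81-fold higher number from compound 2 to compound 4 (1.91 log units; beyond the scatter) as large steps. It also falls behind the group without a ring, with an at least 4.0-fold higher number from compound 1 to compound 4 (0.60 log units; beyond the scatter) as the step.

Open, on these data alone, is whether the sulfonyl or the five-membered aromatic ring carries the loss, as both change together. A phenylsulfonyl group, or a carbonyl bearing the same five-membered ring, would separate them.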